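Three limit values and one aminophenyl change in this series

A few compounds are considered here, and "the series" means these few. Any claim that something is new, unique, unknown or untested is made for them only; others in the source may bear on it.

Working notes on the series in a functional assay on HL-60 cells (Homo sapiens) for cytotoxicity, read by MTT assay, with a stated time of 48 h; a lower number here means a stronger inhibitor, a higher number a weaker inhibitor. Compound 1 `Fc1cccc(-c2nc(Nc3ccccc3)c3ccccc3n2)c1` gives > 50000 nM, which is a limit of the assay and not a number. Compound 2 `Fc1ccc2nc(-c3ccccc3)nc(Nc3ccccc3)c2c1` likewise gives > 50000 nM, again a limit. Compound 3 `Fc1cccc(-c2nc(Nc3cccc(Cl)c3)c3cc(F)ccc3n2)c1` returns > 50000 nM, also only a limit. Compound 3 therefore stands with the other two at the limit of > 50000 nM in this assay, at which 3 of the 3 values shown sit, and no order among the three can be read. Compound 4 `Nc1ccccc1Nc1nc(-c2cccc(F)c2)nc2ccc(F)cc12` is not yet measured. It differs from compound 3 in one place: 2-aminophenyl in place of 3-chlorophenyl on a nitrogen on an aromatic ring. For the measured compounds named here, no step between measured compounds is available, so nothing measured tells the size of this change. The expectation for compound 4 is a step of an at least 1.2-fold lower number from compound 3 to compound 4 (0.09 log units; that floor lies within the scatter), most likely still near the limit, giving an estimate of 40000 nM with a range from 8000 nM to 120000 nM.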

Compound 4, half-maximal inhibitory concentration: 41300 nM
Compound 4: the middle estimate sits 1.0-fold (0.01 log units) below what was measured; the range from low to high includes it.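

In this assay, for the compounds shown here, compound 4 gives 41300 nM, the only value shown that is a number and not a limit. Placing 2-aminophenyl in place of 3-chlorophenyl on a nitrogen on an aromatic ring gives an at least 1.2-fold lower number from compound 3 to compound 4 (0.08 log units; that floor lies within the scatter). That step is only a floor, and its true size stays unread, since compound 3 is itself a limit: the limit of > 50000 nM in this assay, at which 3 of the 4 values shown sit.

The compounds shown leave open whether the amine is what matters on this ring. A hydroxyl or a carboxylic acid in place of that amine would bear on this question.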